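This account rests on a few compounds, and the source may have more. Where it says the series, first, only, none or still open, it means among the compounds named here.

Compound 1 `CCCCc1ccc(-c2cc(=O)c3c(o2)C(CC)(CC)C(=O)C(CC)=C3O)cc1` and compound 2 `CCC1=C(O)c2c(oc(-c3ccc(F)cc3)cc2=O)C(CC)(CC)C1=O` share the same core and differ only in the group carried on the outer aromatic ring. In a functional assay on KBVIN cells (Homo sapiens) for antiproliferative activity, read by sulforhodamine B assay, with a stated time of 3 days (on this read-out higher numbers stand for an effect only at larger amounts of compound and lower numbers for an effect already at smaller amounts), compound 1 gives 37 uM, whereas compound 2 gives 1.85 uM. For the measured compounds named here, the single measured step, a 20-fold lower number from compound 1 to compound 2 (1.30 log units; beyond the scatter), shows that exchanging the group on that outer ring can shift the read-out considerably. Going by the values given here, compound 2 therefore holds the lower of the two numbers measured so far, and compound 1 is the only other point of comparison.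

Compound 3 `CCC1=C(O)c2c(oc(-c3ccc(OC)c(Cl)c3)cc2=O)C(CC)(CC)C1=O` is the next candidate: 3-chloro-4-methoxyphenyl in place of 4-fluorophenyl on an aromatic carbon. Among the compounds with values here, the one measured step bears on this change only loosely, because a 20-fold lower number from compound 1 to compound 2 (1.30 log units; beyond the scatter) concerned a different pair of groups on the same outer ring; it was large, so the outer ring clearly influences the read-out, but it gives no direction for a 3-chloro-4-methoxyphenyl group. The expectation for compound 3 is accordingly a modest step, a 1.9-fold higher number from compound 2 to compound 3 (0.28 log units; within the scatter), with a wide band of uncertainty. Compound 3 is estimated at 3.5 uM in this assay, expected to fall between 0.8 uM and 15 uM.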

Compound 3, concentration for half-maximal effect: 1.37 uM
The estimate for compound 3 lay 2.6-fold (0.41 log units) above the measured number; measured number inside the range.
By their numbers in this assay, from the lowest: compounds 3 and 2 (each within the scatter of the next); then compound 1.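

In this assay, 3-chloro-4-methoxyphenyl in place of 4-fluorophenyl gives a 1.4-fold lower number from compound 2 to compound 3 (0.13 log units; within the scatter), so this exchange on the aromatic carbon next to the ring oxygen, which brings in 9 heavy atoms in place of 7 and 1 hydrogen-bond acceptor in place of 0, leaves the number unchanged within the usual scatter. For the compounds shown here, the earlier step showed only that the group on this outer ring can matter a great deal; this result adds that two quite different sets of groups on that ring, a lone fluoro and a chloro with a methoxy, give numbers that cannot be told apart, while the butyl-bearing compound 1 stands at 37 uM in the same test. No measurement is available that explains why these two groups give such similar numbers.

Going by these compounds, what the chloro and the methoxy group each contribute on their own remains open. Also open, on these data alone, is how the read-out would respond if an amine, a carboxylic acid or a shorter chain such as ethyl sat on this outer ring instead.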